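Chlorophenyl to Difluorophenyl on a Shared Core

This account rests on a few compounds, and the source may have more. Where it says the series, first, only, none or still open, it means among the compounds named here.

Measured so far:
Compound 1, `CCOC(=O)C1=Cc2ccccc2OC1(OCc1cc(-c2ccc(OC)cc2)no1)C(F)(F)F`: in a functional assay on DU-145 cells (Homo sapiens) for inhibition, read by MTT assay, with a stated time of 24 h (a higher number here means a weaker inhibitor, a lower number a stronger inhibitor), compound 1 reaches only the limit > 150000 nM.
Compound 2, `O=C(O)C1=Cc2ccccc2OC1(OCc1cc(-c2ccc(F)cc2F)no1)C(F)(F)F`: in this assay compound 2 also reaches only the limit > 150000 nM.
Compound 3, `CCOC(=O)C1=Cc2ccccc2OC1(OCc1cc(-c2ccc(Cl)cc2)no1)C(F)(F)F`: in this assay compound 3 gives 18200 nM.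

Within the data shown here, compound 3 therefore holds the only real number; the other two values are limits (the limit of > 150000 nM in this assay, at which 2 of the 3 values shown sit). Among the measured compounds shown here, the single measured step, an at least 8.2-fold lower number from compound 1 to compound 3 (0.91 log units; beyond the scatter), shows that changing the group on the phenyl ring can move the number beyond the scatter. Compound 4, `CCOC(=O)C1=Cc2ccccc2OC1(OCc1cc(-c2ccc(F)cc2F)no1)C(F)(F)F`, differs from compound 3 by 2,4-difluorophenyl in place of 4-chlorophenyl on an aromatic carbon. For the measured compounds named here, no measured step covers this exact exchange. Compound 2, which also carries the 2,4-difluorophenyl, sits at the limit > 150000 nM in this assay, so a weaker number seems more likely than a stronger one. The expected step is a 2.2-fold higher number from compound 3 to compound 4 (0.34 log units; beyond the scatter). Compound 4 is estimated at 40000 nM, with a range from 15000 nM to 150000 nM.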

Compound 4, half-maximal inhibitory concentration: > 150000 nM
Compound 4 was reported as a limit; the forecaster's own chance of this, stated with the estimate: 35%; at least 3.7-fold (0.57 log units) between middle value and limit.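

Here, 2,4-difluorophenyl in place of 4-chlorophenyl gives an at least 8.2-fold higher number from compound 3 to compound 4 (0.91 log units; beyond the scatter), so this exchange on the shared core moves the number beyond the scatter, just as the change from 4-methoxyphenyl did. The steps from compound 1 and from compound 2 to compound 4 cannot be read, as both ends of each are limits. Compound 3 is now the only compound with a real number, and the others stop at one limit: the limit of > 150000 nM in this assay, at which 3 of the 4 values shown sit.

Still open, from the compounds shown here alone, is how a 4-bromophenyl or an unsubstituted phenyl would read at this position. Also open, going by these compounds, is whether any group here gives a lower number than compound 3 does.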